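A few compounds are considered here, and "the series" means these few. Any claim that something is new, unique, unknown or untested is made for them only; others in the source may bear on it.

Working notes on the series. Three compounds carry a number in an ADME assay on microsomes from liver (Homo sapiens) for metabolic stability, read by LC-MS, with a stated time of 10 min (a higher number here means that more of the compound is left, a lower number that less of the compound is left), so far. Compound 1 `c1cnc2c(c1)CCC[C@@H]2N(CC1CC1)C[C@H]1Cc2c(cccc2N2CCNCC2)CN1` gives 82.1%. Compound 2 `CN(C[C@H]1Cc2c(cccc2N2C[C@@H]3C[C@H]2CN3)CN1)[C@H]1CCCc2cccnc21` gives 100%. Compound 3 `CN(C[C@@H]1Cc2c(cccc2N2CCNCC2)CN1)[C@H]1CCCc2cccnc21` gives 94.2%. Compound 2 therefore holds the highest of the three numbers, but compound 3 sits within the scatter of it, so no order between compound 2 and compound 3 can be read from these two values; compound 1 lies beyond the scatter below compound 2.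

Compound 4 `CCN1CCN(c2cccc3c2C[C@H](CN(C)[C@H]2CCCc4cccnc42)NC3)CC1` has not yet been measured in this assay. It differs from compound 2 in one place: a group of 8 heavy atoms (6 carbon, 2 nitrogen; one six-membered non-aromatic ring with 2 hetero atoms) in place of a group of 7 heavy atoms (5 carbon, 2 nitrogen; 2 five-membered non-aromatic rings with 1 hetero atom each), on an aromatic carbon

Compound 4 shares with compound 3 a six-membered non-aromatic ring with two hetero atoms at this position, and compound 3 with 94.2% stands within the scatter of compound 2 at 100%, while compound 1, also with such a ring but a different substituent on the other nitrogen, gives the lowest number at 82.1%. Compound 4 is therefore expected to come out somewhat below compound 2, with the expected step of a number 12 percentage points lower from compound 2 to compound 4 (beyond the scatter) at the edge of the scatter. The estimate for compound 4 in this assay is 88%, with a range from 72% to 100%.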

Compound 4, percent of the compound remaining: 0%
Estimate against measurement, compound 4: 88 percentage points above; the measured number lies below the stated range.
By their numbers in this assay, from the lowest: compound 4; then compound 1; then compounds 3 and 2 (each within the scatter of the next).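

In this assay, for the compounds shown here, the step to the 4-ethylpiperazin-1-yl group is the first single-place change that can be read, and it is a number 100 percentage points lower from compound 2 to compound 4 (beyond the scatter). This position on the aromatic carbon is therefore not indifferent to what it carries: one exchange of groups, with the rest of the molecule unchanged, spans the distance from the top of the measured values to the bottom. The entering group also has no hydrogen-bond donor by count where the leaving bridged group has one, but this single step changes the ring system, the donor count and the ethyl chain together, so it cannot assign the loss to any one of them. No measurement at hand bears on the cause of this step.

Open, on these data alone, is whether the ethyl chain itself carries the step, which a 4-methylpiperazin-1-yl or a 4-acetylpiperazin-1-yl group at the same aromatic carbon would help to separate. Also open, as far as these compounds go, is whether a morpholin-4-yl group, with oxygen in place of the second ring nitrogen, would stay near compound 2 or fall towards compound 4.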